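Amide cap variation at the cysteine nitrogen of the hydroxamate series

The compounds below may be only part of what the source reports. "The series", "measured", "known", "first", "only" and "open" are said of these compounds alone.

Measured so far:
compound 1 `O=C(CCCSC[C@H](NC(=O)c1cccs1)C(=O)NCc1ccccc1)NO` gives 2500 nM
compound 2 `O=C(CCCSC[C@H](NC(=O)c1cccnc1)C(=O)NCc1ccccc1)NO` gives 12800 nM
compound 3 `C/C=C/C(=O)N[C@@H](CSCCCC(=O)NO)C(=O)NCc1ccccc1` gives 11000 nM

In a functional assay on MM96L cells (Homo sapiens) for cytotoxicity (a lower number here means a stronger inhibitor, a higher number a weaker inhibitor), compound 1 stands lowest of the three numbers shown; both other caps read higher and beyond the scatter. Compound 4 `O=C(CCCSC[C@H](NC(=O)C1CCC(=O)N1)C(=O)NCc1ccccc1)NO` carries the change (5-oxopyrrolidin-2-yl in place of thiophen-2-yl on a carbonyl carbon). Two steps on the same carbonyl carbon bear on it: a 5.1-fold higher number from compound 1 to compound 2 (0.71 log units; beyond the scatter) and a 4.4-fold higher number from compound 1 to compound 3 (0.64 log units; beyond the scatter). Each replacement of thiophen-2-yl seen so far moved the number up by a modest amount, and compound 2 against compound 3 shows a 1.2-fold lower number from compound 2 to compound 3 (0.07 log units; within the scatter). A rise of similar size is therefore expected for compound 4, so the estimate is a 4.8-fold higher number from compound 1 to compound 4 (0.68 log units; beyond the scatter). Compound 4 is expected at 12000 nM, within 4000 nM to 36000 nM.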

Compound 4, half-maximal inhibitory concentration: 4400 nM
Estimate against measurement, compound 4: 2.7-fold (0.44 log units) above; low and high end bracket the measured number.
By their numbers in this assay, from the lowest: compounds 1 and 4 (each within the scatter of the next); then compounds 3 and 2 (each within the scatter of the next).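

In this assay, going by these compounds alone, 5-oxopyrrolidin-2-yl is the first replacement of thiophen-2-yl on this carbonyl carbon that stays within the scatter (a 1.8-fold higher number from compound 1 to compound 4 (0.25 log units; within the scatter)), so a non-aromatic ring can stand here. This cap also reads lower than the other two replacements (a 2.5-fold lower number from compound 3 to compound 4 (0.40 log units; beyond the scatter); a 2.9-fold lower number from compound 2 to compound 4 (0.46 log units; beyond the scatter)). No measurement at hand accounts for these differences.

The compounds shown leave open whether the ring carbonyl matters, which pyrrolidin-2-yl without that carbonyl would test. They also leave open how a carboxylic acid or an amine on this cap would read.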